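Aromatic nitrogen substituent change, compound 3 to compound 4

The source may report more compounds than this note shows. Statements on the series, on what has been measured and on what is new or still open speak of the compounds shown alone.

Measured compounds in an assay for inhibition of Indoleamine 2,3-dioxygenase 1 (Homo sapiens), with stated times of 10 min and 60 min; on this read-out higher numbers stand for weaker inhibition and lower numbers for stronger inhibition:
compound 1, `O=[N+]([O-])c1ccccc1CNc1cc(Br)cc2cn[nH]c12`: > 100000 nM
compound 2, `Oc1ccc(CNc2cc(C(F)(F)F)cc3[nH]ncc23)cc1`: 36700 nM
compound 3, `NCCn1ncc2c(NCc3ccccc3[N+](=O)[O-])cc(C(F)(F)F)cc21`: > 100000 nM

Compound 3 gives only a limit of this assay, > 100000 nM, and no number. Compound 1 likewise stands at a limit, > 100000 nM. For the measured compounds named here, compound 2 is the only member with a measured number, 36700 nM. Going by the values given here, no pair of these three differs in a single place, so no measured step can be drawn among them; the two limits together form (the limit of > 100000 nM in this assay, at which 2 of the 3 values shown sit).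

Compound 4, `CC(C)n1ncc2c(NCc3ccccc3[N+](=O)[O-])cc(C(F)(F)F)cc21`, differs from compound 3 by isopropyl in place of 2-aminoethyl on an aromatic nitrogen. With compound 3 at a limit, the direction of the step cannot be read from a measured difference. A small move toward stronger inhibition is expected in this assay, as compound 4 no longer carries the donor and acceptor that the 2-aminoethyl of compound 3 brings, but the step of an at least 1.2-fold lower number from compound 3 to compound 4 (0.09 log units; that floor lies within the scatter) is expected to stay near the scatter. Compound 4 is therefore estimated at 80000 nM in this assay, with a range from 20000 nM to 300000 nM.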

Compound 4, half-maximal inhibitory concentration: > 100000 nM
Compound 4 gave a limit, no number; the forecaster's own chance of this, stated with the estimate: 55%; at least 1.2-fold (0.09 log units) between middle value and limit.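

Compound 3 and compound 4 both stand at limits in this assay, so no step can be read for isopropyl in place of 2-aminoethyl on an aromatic nitrogen: the limit of > 100000 nM in this assay, at which 3 of the 4 values shown sit. The compounds shown leave open whether this change alters inhibition at all, and in which direction.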